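The source may report more compounds than this note shows. Statements on the series, on what has been measured and on what is new or still open speak of the compounds shown alone.

Measured compounds:
- compound 2 `CS(=O)(=O)c1ccc(C(=O)N2CCC(N(C3CC3)S(=O)(=O)c3cccc(C(F)(F)F)c3)CC2)c(F)c1`, 350 nM in an assay on HEK293 cells for inhibition of Voltage-dependent N-type calcium channel subunit alpha-1B (Homo sapiens), read by FLIPR and calcium flux; on this read-out higher numbers stand for weaker inhibition and lower numbers for stronger inhibition
- compound 1 `CS(=O)(=O)c1ccc(Cl)c(C(=O)N2CCC(N(C3CC3)S(=O)(=O)c3cccc(C(F)(F)F)c3)CC2)c1`, 340 nM in this assay

Compound 2 has the higher of the two numbers, but its distance from compound 1 is a 1.0-fold higher number from compound 1 to compound 2 (0.01 log units; within the scatter), so the two compounds cannot be told apart in this assay.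

Compound 3 `CS(=O)(=O)c1ccc(C(=O)N2CCC(N(C3CC3)S(=O)(=O)c3cccc(C(F)(F)F)c3)CC2)c(C(F)(F)F)c1` differs from compound 2 by trifluoromethyl in place of fluoro on an aromatic carbon, the new group sitting ortho to a large group and meta to a methylsulfonyl group. For the measured compounds named here, the one measured step, which swaps the whole substitution pattern of that ring, bears on it only loosely: it was within the scatter, which suggests that this ring tolerates changes of this kind without a large shift in this assay. Going by the values given here, no measured pair tests a fluoro-to-trifluoromethyl exchange directly, so the expectation rests on that single step. A step of about a 1.3-fold higher number from compound 2 to compound 3 (0.11 log units; within the scatter) is therefore expected, with no clear direction beyond the scatter.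

Compound 3 is estimated at 450 nM in this assay, with a range of 150 nM to 1500 nM.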

Compound 3, half-maximal inhibitory concentration: 21 nM
Beside the measured number, compound 3's estimate is 21-fold (1.33 log units) above it, and the stated range ends above it.
By their numbers in this assay, from the lowest: compound 3; then compounds 1 and 2 (each within the scatter of the next).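

At the aromatic carbon ortho to a large group and meta to a methylsulfonyl group, the choice of substituent matters strongly in this assay: trifluoromethyl in place of fluoro gives a 17-fold lower number from compound 2 to compound 3 (1.22 log units; beyond the scatter), a large step beyond the scatter, and the number falls, which means stronger inhibition. The earlier step, a 1.0-fold higher number from compound 1 to compound 2 (0.01 log units; within the scatter), changed the whole substitution pattern of this ring and stayed within the scatter, so it gave no sign that this one place could carry so much. Nothing shown here accounts for the size of this step.

The compounds shown leave open whether a methyl, a methoxy or a nitrile on this aromatic carbon would give a similar step, or whether it is particular to trifluoromethyl. They also leave open whether trifluoromethyl in place of fluoro would have the same effect with the methylsulfonyl group placed as in compound 1.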